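A Repeated Substitution Tested on Liver Cancer Cells

The compounds below may be only part of what the source reports. "The series", "measured", "known", "first", "only" and "open" are said of these compounds alone.

Compound 1 `COc1ccccc1NC1=C/C(=N/NC(N)=S)C(=O)N=C1Nc1ccccc1OC` and compound 2 `NC(=S)N/N=C1/C=C(Nc2ccc(F)cc2)C(Nc2ccc(F)cc2)=NC1=O` are built on related cores, but the difference between the two cores is not broken down here. In a functional assay on Bel-7402 cells (Homo sapiens) for antiproliferative activity, read by MTT assay, with a stated time of 72 h (on this read-out higher numbers stand for weaker inhibition and lower numbers for stronger inhibition), compound 1 gives 13400 nM, and compound 2 gives 3660 nM, a gap that lies beyond the scatter. Compound 3 `N/C(=N\N=C1\C=C(Nc2ccc(F)cc2)C(Nc2ccc(F)cc2)=NC1=O)SCc1ccccc1` arises from compound 2 through (a group of 11 heavy atoms (8 carbon, 2 nitrogen, 1 sulfur; one six-membered aromatic ring of carbon only) in place of a group of 4 heavy atoms (1 carbon, 2 nitrogen, 1 sulfur; no ring), on a double-bonded nitrogen). In this assay compound 3 gives 7690 nM, so this change made a 2.1-fold higher number from compound 2 to compound 3 (0.32 log units; beyond the scatter). Compound 4 `COc1ccccc1NC1=C/C(=N/N=C(\N)SCc2ccccc2)C(=O)N=C1Nc1ccccc1OC` has not yet been measured; it arises from compound 1 through (a group of 11 heavy atoms (8 carbon, 2 nitrogen, 1 sulfur; one six-membered aromatic ring of carbon only) in place of a group of 4 heavy atoms (1 carbon, 2 nitrogen, 1 sulfur; no ring), on a double-bonded nitrogen), the same change at the same place, and it is the second of two occurrences of this change among the compounds shown. Among the measured compounds shown here, the step is expected to repeat in size, so the step from compound 1 to compound 4 in this assay is estimated as a 2.0-fold higher number from compound 1 to compound 4 (0.30 log units; within the scatter), resting on the single measured step of a 2.1-fold higher number from compound 2 to compound 3 (0.32 log units; beyond the scatter) and on nothing else, which leaves the estimate rather uncertain. Compound 4 is therefore expected to give about 27000 nM, within an estimated range from 10000 nM to 70000 nM.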

Compound 4, half-maximal inhibitory concentration: 13100 nM
Estimate against measurement, compound 4: 2.1-fold (0.31 log units) above; measured number inside the range.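

In this assay, putting the larger group with its six-membered aromatic ring in place of the small group without a ring gives a 1.0-fold lower number from compound 1 to compound 4 (0.01 log units; within the scatter), so on this core the two numbers cannot be told apart. The earlier step on the other core looks larger when read alone, but the two steps are no further apart than two such steps normally scatter, so these compounds give no sign that the core alters the effect of the change: the same change on two cores in this assay, a 2.1-fold higher number (0.32 log units; beyond the scatter) from compound 2 to compound 3 and a 1.0-fold lower number (0.01 log units; within the scatter) from compound 1 to compound 4, 2.1-fold (0.33 log units) apart, within the scatter of two such steps. This does not prove that the step has one fixed size, since two pairs tested in one assay are too few to show that, and they cannot rule out a small difference between the cores or explain either result.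

The compounds shown leave open whether a group ending in an amine or a carboxylic acid, or a longer chain with no ring, would behave in the same way in place of the entering group. They also leave open whether the step would hold on any further core.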